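A Shared Core, Three Benzyl Groups, One Open Question

The compounds below may be only part of what the source reports. "The series", "measured", "known", "first", "only" and "open" are said of these compounds alone.

Of the compounds shown here, three built on one shared core have been tested in a toxicity assay on NIH3T3 cells (Mus musculus) for cytotoxicity, read by resazurin assay (a higher number here means that more compound is needed for the effect, a lower number that less compound is needed), and all of them sit far up the scale. Compound 1 `COC(=O)c1ccc(NCc2cncn2Cc2cccc(Cl)c2)cc1-c1ccccc1` carries a 3-chlorophenyl on a saturated chain carbon bound to an aromatic nitrogen. In this assay compound 1 gives only a limit, > 10000 nM, rather than a number. Compound 2 `COC(=O)c1ccc(NCc2cncn2Cc2ccc(C)cc2)cc1-c1ccccc1` carries a 4-methylphenyl at the same place, and in this assay compound 2 gives 50000 nM. Compound 3 `COC(=O)c1ccc(NCc2cncn2Cc2ccc(F)cc2F)cc1-c1ccccc1` carries a 2,4-difluorophenyl there. In this assay compound 3 also gives only a limit, > 1000 nM. Because of the limit of > 1000 nM in this assay, at which 1 of the 3 values shown sits, and the limit of > 10000 nM in this assay, at which 1 of the 3 values shown sits, the steps between these compounds cannot be sized: a step that the limit leaves unreadable from compound 1 to compound 2, a step that the two limits leave unreadable from compound 1 to compound 3 and a step that the limit leaves unreadable from compound 2 to compound 3. Compound 3 thus stands with no readable difference from compound 1 or compound 2.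

For the measured compounds named here, compound 4 `COC(=O)c1ccc(NCc2cncn2Cc2cccc(N)c2)cc1-c1ccccc1` has not yet been measured. 3-aminophenyl in place of 2,4-difluorophenyl on a saturated chain carbon bound to an aromatic nitrogen None of the measured steps touches the 3-aminophenyl, and none of them can be sized, so no direction can be drawn from them; the only guide is that every value so far lies high. Compound 4 is therefore expected to sit similarly high, with a step that the limit leaves unreadable from compound 3 to compound 4 as a step that cannot be told apart from none. In this assay compound 4 is estimated at 30000 nM, expected to fall between 5000 nM and 100000 nM.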

Compound 4, half-maximal effective concentration: > 10000 nM
Compound 4 gave a limit, no number (the forecaster's own chance of this, stated with the estimate: 60%); the middle value does not contradict the limit.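

In this assay compound 4 gives > 10000 nM, which is a limit and not a number. For the compounds shown here, no step between compound 4 and compound 1, compound 2 or compound 3 can be read, so this result adds no size to any comparison. The compounds shown leave open whether changing the benzyl group shifts the value at all.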